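The compounds below may be only part of what the source reports. "The series", "measured", "known", "first", "only" and "open" are said of these compounds alone.

Three close relatives of one shared core have been tested in an ADME assay on Vero cells (Chlorocebus sabaeus) for cytotoxicity, with a stated time of 72 h; a lower number here means a stronger inhibitor, a higher number a weaker inhibitor: compound 1 with the structure `CCOC(=O)c1cc(-c2cccc(OCc3cccc(C(F)(F)F)c3)c2)on1`, compound 2 with `CCOC(=O)c1cc(-c2cccc(OCc3cccc(Cl)c3)c2)on1` and compound 3 with `CCOC(=O)c1cc(-c2cccc(OCc3cccc(OC(F)(F)F)c3)c2)on1`. Compound 1 reaches only the limit of the assay, > 128000 nM, which is not a number. Compound 2 likewise stops at the limit, > 128000 nM. Going by the values given here, compound 3 is the single member with a measured number, giving 101000 nM, so it stands as the only firm point in the set. Two of the three results thus rest at the limit of > 128000 nM in this assay, at which 2 of the 3 values shown sit.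

The next compound, compound 4 with the structure `CCOC(=O)c1cc(-c2cccc(OCc3cccc(C#N)c3)c2)on1`, differs from compound 3 by cyano in place of trifluoromethoxy on an aromatic carbon. The steps already measured at this same position give a rough guide: an at least 1.2-fold lower number from compound 1 to compound 3 (0.10 log units; that floor lies within the scatter), and an at least 1.2-fold lower number from compound 2 to compound 3 (0.10 log units; that floor lies within the scatter), while a step that the two limits leave unreadable from compound 1 to compound 2. Every change at this spot has therefore either been unreadable or small enough to sit within the usual scatter. On that basis the move to a cyano group is expected to bring no change beyond the scatter in this assay, with the number staying near the present limit or slightly above the value of compound 3. The estimate for compound 4 is 120000 nM, within a range from 55000 nM to 260000 nM, which is expected to mean a 1.2-fold higher number from compound 3 to compound 4 (0.07 log units; within the scatter).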

Compound 4, half-maximal inhibitory concentration: > 128000 nM
Compound 4 ended at the assay's limit (the forecaster's own chance of this, stated with the estimate: 55%); middle value at least 1.0-fold (0.02 log units) away from the limit.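

Putting cyano in place of trifluoromethoxy on an aromatic carbon in this assay gives an at least 1.2-fold higher number from compound 3 to compound 4 (0.10 log units; that floor lies within the scatter). This adds a group with a triple bond and fewer heavy atoms to those tried at this position, yet the floor of that step still lies within the scatter, so the change shows no clear effect. The steps that link compound 1 and compound 2 to compound 4 cannot be read, as both ends of each are limits, and with four different groups at this position, this assay now yields a single measured number, while the rest of the set gives only this: the limit of > 128000 nM in this assay, at which 3 of the 4 values shown sit.

The compounds shown leave open whether a quite different group at this position, such as an amine or a carboxylic acid, would give a number clearly lower than that of compound 3. They also leave open what the true numbers behind the limits of compound 1, compound 2 and compound 4 are, so these three compounds cannot be ranked against one another.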